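Swapping the heteroaryl amide of compound 1 for a chloroquinoline

The compounds below may be only part of what the source reports. "The series", "measured", "known", "first", "only" and "open" are said of these compounds alone.

Compound 1 `O=C(NC1CCCCC1)NS(=O)(=O)N1CCC(CCNC(=O)c2cscn2)CC1` gives 23% in a functional assay on the whole organism (blood) with Rattus norvegicus as the target, with stated times of 24 h and 1 h, at a dose of 5 mg/kg by the intraperitoneal route (a higher number here means a stronger effect of the compound at the dose given, a lower number a weaker effect), the highest of the three numbers shown. Compound 3 `O=C(NC[C@@H]1C[C@@H]2C=C[C@@H]1C2)NS(=O)(=O)N1CCC(CCNC(=O)c2ccc3ccccc3n2)CC1` gives 21%, which lies within the scatter of compound 1, while compound 2 `CCCNC(=O)NS(=O)(=O)N1CCC(CCNC(=O)c2cscn2)CC1` gives 10%. Among the measured compounds shown here, the one measured step, a number 13 percentage points lower from compound 1 to compound 2 (beyond the scatter), changes a group on an amide-type nitrogen, not the part altered here, so it does not bear directly on the new change. Compound 4 `O=C(NC1CCCCC1)NS(=O)(=O)N1CCC(CCNC(=O)c2cc(Cl)cc3cccnc23)CC1` differs from compound 1 by 6-chloroquinolin-8-yl in place of 1,3-thiazol-4-yl on a carbonyl carbon. Compound 3 carries a larger fused bicyclic group at the same carbonyl and shows a value close to compound 1, but its amine part also differs, so no step can be read from it. For compound 4 a step of a number 1 percentage points lower from compound 1 to compound 4 (within the scatter) is expected, none beyond the scatter, giving an estimate of 22% with a range from 8% to 36%.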

Compound 4, a percentage reported as activity, at one dose (the size of the read-out at that dose, not a potency): 52%
Compound 4: middle estimate off by 30 percentage points, on the low side; measured number outside the range, above it.
By their numbers in this assay, from the lowest: compound 2; then compounds 3 and 1 (each within the scatter of the next); then compound 4.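

In this assay, the group on the carbonyl carbon clearly matters: 6-chloroquinolin-8-yl in place of 1,3-thiazol-4-yl gives a number 29 percentage points higher from compound 1 to compound 4 (beyond the scatter). The earlier compounds shown here gave no clean step at this position, since compound 3 also differs in its amine part. No available measurement explains the rise.

Still open, as far as these compounds go, is whether the gain needs the chlorine or comes from the quinoline alone, which a plain quinolin-8-yl group would test. From the compounds shown here alone, whether it also holds with propyl in place of cyclohexyl remains unknown.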